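The compounds below may be only part of what the source reports. "The series", "measured", "known", "first", "only" and "open" are said of these compounds alone.

Measured compounds in a functional assay on isolated protein for inhibition of Glucose-dependent insulinotropic receptor (Rattus norvegicus), read by HTRF and cAMP accumulation; on this read-out higher numbers stand for an effect only at larger amounts of compound and lower numbers for an effect already at smaller amounts:
compound 1 `CCC1(OC(=O)N2CCC(Oc3ncnc(Oc4ccc(S(C)(=O)=O)nc4C)c3F)CC2)CC1` gives 333 nM
compound 2 `Cc1nc(S(C)(=O)=O)ccc1Oc1ncnc(OC2CCN(C(=O)OC3(C(F)(F)F)CCC3)CC2)c1F` gives 63.3 nM
compound 3 `Cc1nc(S(C)(=O)=O)ccc1Oc1ncnc(OC2CCN(C(=O)SC3CCC3)CC2)c1F` gives 77.4 nM

Compound 3 stands second highest of the three; its nearest neighbour is compound 2, since a 1.2-fold higher number from compound 2 to compound 3 (0.09 log units; within the scatter), and its furthest is compound 1, since a 4.3-fold lower number from compound 1 to compound 3 (0.63 log units; beyond the scatter). Compound 4 `CCC(F)(F)C(=O)N1CCC(Oc2ncnc(Oc3ccc(S(C)(=O)=O)nc3C)c2F)CC1` differs from compound 3 by 1,1-difluoropropyl in place of cyclobutylsulfanyl on a carbonyl carbon. Going by the values given here, the steps that bear on this are the two earlier changes at the same carbonyl carbon: a 4.3-fold lower number from compound 1 to compound 3 (0.63 log units; beyond the scatter) and a 1.2-fold higher number from compound 2 to compound 3 (0.09 log units; within the scatter), both modest or within the scatter. Among the compounds with values here, no measured compound carries a chain without a ring or heteroatom at this position, so the expectation is loosely held. Compound 4 is expected near 150 nM, within 50 nM to 500 nM, a step of a 1.9-fold higher number from compound 3 to compound 4 (0.29 log units; within the scatter).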

Compound 4, half-maximal effective concentration: 69.2 nM
Compound 4: middle estimate off by 2.2-fold (0.34 log units), on the high side; the range from low to high includes it.
By their numbers in this assay, from the lowest: compounds 2, 4 and 3 (each within the scatter of the next); then compound 1.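

In this assay, the open-chain 1,1-difluoropropyl group matches the cyclobutylsulfanyl group (a 1.1-fold lower number from compound 3 to compound 4 (0.05 log units; within the scatter)) and the larger group of compound 2 (a 1.1-fold higher number from compound 2 to compound 4 (0.04 log units; within the scatter)). Among these compounds, then, neither a ring nor an oxygen or sulfur attached to the carbonyl carbon is required at this position. Going by these compounds alone, the one step here beyond the scatter is the modest one (a 4.8-fold lower number from compound 1 to compound 4 (0.68 log units; beyond the scatter)), and no measurement offered here accounts for it. Still open, on these data alone, is how a longer chain or an amine on the carbonyl carbon would read out in this assay.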